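Notes on the step to compound 4

The source may hold more compounds than are shown below. What is called first, only, known or untested is meant among the compounds shown, and "the series" means these compounds.

Values in a functional assay on HEL cells (Homo sapiens); on this read-out lower numbers stand for higher toxicity in this test and higher numbers for lower toxicity in this test:
- compound 1 `CC(=O)NC1=CS(=O)(=O)O[C@@]12[C@@H](CO[Si](C)(C)C(C)(C)C)O[C@@H](n1cc(C)c(=O)n(C)c1=O)[C@@H]2O[Si](C)(C)C(C)(C)C`: > 200000 nM (a limit)
- compound 2 `Cc1cn([C@@H]2O[C@@H]3COC(=O)[C@]3(OS(C)(=O)=O)[C@H]2O)c(=O)[nH]c1=O`: >= 36000 nM (a limit)
- compound 3 `C=C(C)C(=O)NC(=O)NC1=CS(=O)(=O)O[C@@]12[C@@H](CO[Si](C)(C)C(C)(C)C)O[C@@H](n1cc(C)c(=O)n(C)c1=O)[C@@H]2O[Si](C)(C)C(C)(C)C`: 1200 nM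

Among the compounds with values here, compound 3, at 1200 nM, holds the only actual number in the set. Compound 1 gives only a limit: the limit of > 200000 nM in this assay, at which 1 of the 3 values shown sits. Compound 2 also gives only a limit: the limit of >= 36000 nM in this assay, at which 1 of the 3 values shown sits.

In compound 4 `Cc1cn([C@@H]2O[C@H](CO[Si](C)(C)C(C)(C)C)[C@@]3(OS(=O)(=O)C=C3NCC(=O)C(=O)O)[C@H]2O[Si](C)(C)C(C)(C)C)c(=O)n(C)c1=O` the shared core stays, and the change is (carboxycarbonyl)methyl in place of ((1-methylethenyl)carbonyl)carbamoyl on an amine nitrogen. This removes the ((1-methylethenyl)carbonyl)amino part along with the rest of the leaving group.

Within the data shown here, one measured step bears on this: an at least 160-fold lower number from compound 1 to compound 3 (2.22 log units; beyond the scatter), a large step beyond the scatter that came with adding that same part. Among the measured compounds shown here, compound 2 offers no single-place step to any other compound. For the measured compounds named here, no measured step covers the entering (carboxycarbonyl)methyl, so its own contribution remains unknown.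

Compound 4 loses the part whose arrival went with an at least 160-fold lower number from compound 1 to compound 3 (2.22 log units; beyond the scatter), so the earlier shift is expected to be largely undone. The step expected in this assay is a 50-fold higher number from compound 3 to compound 4 (1.70 log units; beyond the scatter), large and towards a higher number, meaning lower toxicity in this test. For compound 4 the estimated value is 60000 nM, with an expected range of 8000 nM to 250000 nM. A report as a limit alone would be no surprise.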

Compound 4, half-maximal cytotoxic concentration: 146000 nM
Compound 4: the middle estimate sits 2.4-fold (0.39 log units) below what was measured; the measured number falls inside the stated range.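

In this assay, within the data shown here, a 120-fold higher number from compound 3 to compound 4 (2.09 log units; beyond the scatter), so the low number of compound 3 does not survive the exchange of ((1-methylethenyl)carbonyl)carbamoyl for (carboxycarbonyl)methyl on this amine nitrogen, and compound 4 gives an actual number at the high end of the series, where the earlier compounds gave only limits. Against the acetyl group of compound 1, the comparison reads an at least 1.3-fold lower number from compound 1 to compound 4 (0.13 log units; that floor lies within the scatter), so (carboxycarbonyl)methyl cannot be separated from acetyl at this position. The value of compound 1 is only a limit: the limit of > 200000 nM in this assay, at which 1 of the 4 values shown sits.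

Compound 3 is the only compound shown with a low number, which leaves open whether that number depends on the 1-methylethenyl part, on the carbamoyl link or on the whole ((1-methylethenyl)carbonyl)carbamoyl group. An unsubstituted carbamoyl group, a free amine or a saturated longer chain on this nitrogen would separate these possibilities, while compound 2 has no single-place link to the others and adds nothing to this question.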